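Swapping bromo for methoxy on a bromophenyl ether

This account rests on a few compounds, and the source may have more. Where it says the series, first, only, none or still open, it means among the compounds named here.

Measured in a functional assay on HeLa cells (Homo sapiens) for inhibition, with a stated time of 72 h; a higher number here means a weaker inhibitor, a lower number a stronger inhibitor:
- Compound 1 `O=c1[nH]c(=O)n([C@H]2C[C@H](O)[C@@H](CO)O2)cc1COc1cccc(Br)c1`: 15000 nM
- Compound 2 `O=c1[nH]c(=O)n([C@H]2C[C@H](O)[C@@H](CO)O2)cc1COc1ccc(Br)cc1`: 25000 nM

Among the compounds with values here, compound 2 stands level with compound 1 in this assay, as the only measured step, a 1.7-fold higher number from compound 1 to compound 2 (0.22 log units; within the scatter), places 4-bromophenyl where 3-bromophenyl stood. Compound 3 `COc1ccc(OCc2cn([C@H]3C[C@H](O)[C@@H](CO)O3)c(=O)[nH]c2=O)cc1` differs from compound 2 by methoxy in place of bromo on an aromatic carbon. Within the data shown here, no measured step covers this exchange, and the single step available is small, so no change beyond the scatter is expected. The expected change is a 1.1-fold lower number from compound 2 to compound 3 (0.06 log units; within the scatter). Compound 3 is estimated at 22000 nM, with an expected range of 9000 nM to 55000 nM.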

Compound 3, half-maximal inhibitory concentration: 200000 nM
Compound 3: the middle estimate sits 9.1-fold (0.96 log units) below what was measured; the whole stated range lies below it.
By their numbers in this assay, from the lowest: compounds 1 and 2 (each within the scatter of the next); then compound 3.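

In this assay the earlier pair showed bromo moving around the ring with no change beyond the scatter, but this aromatic carbon does not accept every group: methoxy in place of bromo brings an 8.0-fold higher number from compound 2 to compound 3 (0.90 log units; beyond the scatter), a clear loss. Set against the 3-bromophenyl compound, the 4-methoxyphenyl group gives a 13-fold higher number from compound 1 to compound 3 (1.12 log units; beyond the scatter), so the exchange of group counts for far more here than the shift of bromo. Nothing available explains this loss.

On these data alone, it remains open whether a chloro, a methyl or an amine at this place would fall with methoxy or stay with bromo. As far as these compounds go, it also remains open how methoxy would behave on the other ring position.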